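Swapping the Aryl Substituent on Compound 3

This account rests on a few compounds, and the source may have more. Where it says the series, first, only, none or still open, it means among the compounds named here.

Measured so far in an assay on HEK293 cells for activation of Kir3.1/Kir3.2 (Homo sapiens), read by thallium flux; a lower number here means a smaller maximal response, a higher number a larger maximal response:
compound 1, `O=C(Cn1nnc(-c2ccccc2)n1)NC1CC2CCC1C2`: 13%
compound 2, `CC1CC1c1cc(NC(=O)Cn2nnc(-c3ccccc3)n2)n(C2CCCCC2)n1`: 78%
compound 3, `Cc1cc(NC(=O)Cn2nnc(-c3ccc(F)cc3)n2)n(C2CCCCC2)n1`: 92%

Among these three numbers, compound 3 stands highest. Its nearest neighbour is compound 2, whose value lies lower by a margin beyond the usual scatter, and compound 1 lies far below both. Compound 2 and compound 3 differ from each other in more than one place, so their two values alone do not show what any single change does.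

Compound 4, `Cc1cccc(-c2nnn(CC(=O)Nc3cc(C)nn3C3CCCCC3)n2)c1`, has not yet been measured. It differs from compound 3 in one place: 3-methylphenyl in place of 4-fluorophenyl on an aromatic carbon. For the measured compounds named here, no pair of measured compounds differs by only this change, so nothing measured shows how large such a step is.

In this assay compound 4 is expected to give about 82%, within a range from 58% to 100%. The estimated step of a number 10 percentage points lower from compound 3 to compound 4 (within the scatter) is expected to be small, either toward a somewhat lower value or none beyond the scatter.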

Compound 4, largest response reached (Emax), in percent of the reference or control that the assay uses: 93%
Estimate against measurement, compound 4: 11 percentage points below, within the range that was stated.
By their numbers in this assay, from the lowest: compound 1; then compound 2; then compounds 3 and 4 (each within the scatter of the next).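

In this assay, for the compounds shown here, placing 3-methylphenyl instead of 4-fluorophenyl on the aromatic carbon between two ring nitrogen atoms gives a number 1 percentage points higher from compound 3 to compound 4 (within the scatter), the first single-place step that can be read at this position. The earlier compounds shown here could not show this, since they differ from one another in more than one place. It shows that, of these two aryl groups, neither the fluorine of one nor the methyl of the other sets the maximal response apart, though nothing measured here explains why the two read alike.

The compounds shown leave open whether an unsubstituted phenyl on the same core would read alike, and whether an amine or a carboxylic acid on the phenyl ring would keep the response at this level. They also leave open whether a saturated cyclohexyl ring could take the place of the aryl group.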